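Phenyl for Cyclopentyl at the Amide Carbonyl: Toxicity Outlook

The source may hold more compounds than are shown below. What is called first, only, known or untested is meant among the compounds shown, and "the series" means these compounds.

Compound 1 `COc1ccc(-c2cnc(NC(=O)C3CCCC3)n2C)cc1`: in a toxicity assay on THP-1 cells (Homo sapiens) for inhibition (on this read-out lower numbers stand for higher toxicity in this test and higher numbers for lower toxicity in this test), compound 1 reaches only the assay limit > 100000 nM.
Compound 2 `Cn1c(-c2cccc(Br)c2)cnc1NC(=O)c1ccc(F)cc1`: in this assay compound 2 likewise reaches only the assay limit > 50000 nM.

Compound 1 therefore stands at a limit rather than at a number, and the second value shown is a limit as well the limit of > 100000 nM in this assay, at which 1 of the 2 values shown sits (the limit of > 50000 nM in this assay, at which 1 of the 2 values shown sits). Compound 3 `COc1ccc(-c2cnc(NC(=O)c3ccccc3)n2C)cc1` carries phenyl in place of cyclopentyl on a carbonyl carbon. Within the data shown here, no step between measured compounds is at hand, so the expected step of a number no higher from compound 1 to compound 3 (the limit leaves the size open) is none beyond the scatter, with compound 3 expected to stay at the limit. For compound 3 the estimate in this assay is 100000 nM, within 30000 nM to 300000 nM.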

Compound 3, half-maximal cytotoxic concentration: > 100000 nM
Compound 3 ended at the assay's limit (the forecaster's own chance of this, stated with the estimate: 85%); the middle value sits exactly at the limit.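

Compound 1 and compound 3 both stop at a limit in this assay, so no step between them can be read: the limit of > 100000 nM in this assay, at which 2 of the 3 values shown sit.

The compounds shown leave open whether phenyl in place of cyclopentyl on a carbonyl carbon changes this read-out at all.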